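Tert-butyl to 2-hydroxyethyl on the shared core

A few compounds are considered here, and "the series" means these few. Any claim that something is new, unique, unknown or untested is made for them only; others in the source may bear on it.

Among the measured compounds shown here, compound 2 `CC(C)(C)c1cn(C[C@H](O)[C@H]2OC(=O)C(OCc3ccccc3)=C2OCc2ccccc2)nn1` is the single compound with a number: in a functional assay on SW-620 cells (Homo sapiens) for antiproliferative activity, read by MTT assay, with a stated time of 72 h (on this read-out higher numbers stand for weaker inhibition and lower numbers for stronger inhibition), compound 2 gives 35800 nM. Compound 1 `CCCCCc1ccc(-c2cn(C/C=C3\OC(=O)C(OCc4ccccc4)=C3OCc3ccccc3)nn2)cc1` reaches only a limit of this assay, > 100000 nM; that is the limit of > 100000 nM in this assay, at which 1 of the 2 values shown sits. Compound 3 `O=C1O[C@H]([C@@H](O)Cn2cc(CCO)nn2)C(OCc2ccccc2)=C1OCc1ccccc1` differs from compound 2 by 2-hydroxyethyl in place of tert-butyl on an aromatic carbon. For the measured compounds named here, no measured step guides this change, so the direction is open. The step of a 1.5-fold higher number from compound 2 to compound 3 (0.19 log units; within the scatter) is expected to be small, close to the scatter, leaning if anything toward weaker inhibition. Compound 3 is estimated at 55000 nM, between 15000 nM and 150000 nM, with a real chance that this assay returns only a limit.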

Compound 3, half-maximal inhibitory concentration: > 100000 nM
Compound 3: no number, only a limit (the forecaster's own chance of this, stated with the estimate: 30%); middle value at least 1.8-fold (0.25 log units) away from the limit.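

At this aromatic carbon, 2-hydroxyethyl in place of tert-butyl is not a neutral change in this assay: the step is an at least 2.7-fold higher number from compound 2 to compound 3 (0.44 log units; beyond the scatter). Compound 3 gives only a limit, > 100000 nM. The one numeric value on this core therefore belongs to the tert-butyl compound, and the other values shown sit at the limit: the limit of > 100000 nM in this assay, at which 2 of the 3 values shown sit.

On these data alone, whether the weaker inhibition follows the hydroxyl or the loss of the branched carbon chain remains open. An isopropyl group, an n-butyl chain or a 3-hydroxypropyl chain at this carbon would help separate the two.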